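Replacing bromine-bearing benzyl with a methoxybenzyl arm

The source may report more compounds than this note shows. Statements on the series, on what has been measured and on what is new or still open speak of the compounds shown alone.

Three measured compounds share one core, a bis(trifluoromethyl)benzenesulfonamide joined through a saturated chain to a benzylamine. Compound 1 `O=S(=O)(NCCCCNCc1ccc(Br)cc1)c1cc(C(F)(F)F)cc(C(F)(F)F)c1` gives 2200 nM in a functional assay on BE(2)-C cells (Homo sapiens) for inhibition, read by MTT assay, with a stated time of 72 h; a higher number here means a weaker inhibitor of growth, a lower number a stronger inhibitor of growth. Compound 2 `O=S(=O)(NCCCNCc1ccc(Cl)c(Cl)c1)c1cc(C(F)(F)F)cc(C(F)(F)F)c1` gives 2900 nM in this assay, and compound 3 `O=S(=O)(NCCCNCc1ccc(Br)cc1)c1cc(C(F)(F)F)cc(C(F)(F)F)c1` gives 2700 nM. All three sit close together: the step of a 1.3-fold higher number from compound 1 to compound 2 (0.12 log units; within the scatter), the step of a 1.2-fold higher number from compound 1 to compound 3 (0.09 log units; within the scatter) and the step of a 1.1-fold lower number from compound 2 to compound 3 (0.03 log units; within the scatter) are each within the scatter, so compound 3 stands among equals rather than above or below any of them.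

Compound 4 `COc1ccccc1CNCCCNS(=O)(=O)c1cc(C(F)(F)F)cc(C(F)(F)F)c1` has not yet been measured. Its change from compound 3 is 2-methoxyphenyl in place of 4-bromophenyl on a saturated chain carbon bound to an amine nitrogen. Among the compounds with values here, the nearest precedent is the swap of the aryl group on the benzyl carbon, a 1.1-fold lower number from compound 2 to compound 3 (0.03 log units; within the scatter), which moved nothing beyond the scatter. Within the data shown here, no measured step, however, exchanges a halogen-bearing ring for a methoxy-bearing one, so the precedent is thin. On that basis compound 4 is expected to land close to compound 3, with the step of a 1.1-fold higher number from compound 3 to compound 4 (0.05 log units; within the scatter) estimated to lie within the scatter. The estimate for compound 4 is 3000 nM, with a range from 1200 nM to 7500 nM.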

Compound 4, concentration for 50% growth inhibition: 3600 nM
Estimate against measurement, compound 4: 1.2-fold (0.08 log units) below; low and high end bracket the measured number.
By their numbers in this assay, from the lowest: compounds 1, 3, 2 and 4 (each within the scatter of the next).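

In this assay, a ring bearing a halogen gives way to 2-methoxyphenyl on the saturated chain carbon bound to an amine nitrogen without leaving the scatter, whether the ring that leaves is 4-bromophenyl (a 1.3-fold higher number from compound 3 to compound 4 (0.12 log units; within the scatter)) or 3,4-dichlorophenyl (a 1.2-fold higher number from compound 2 to compound 4 (0.09 log units; within the scatter)). Within the data shown here, this is the first sign that the number at this place does not depend on a halogen, since the entering group has none and carries a hydrogen-bond acceptor. The comparison that also alters the chain stays within the scatter as well (a 1.6-fold higher number from compound 1 to compound 4 (0.21 log units; within the scatter)), and nothing at hand offers an explanation for any of these results.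

All four compounds lie within the scatter of one another, so no group shown here separates itself at this place. Still open, as far as these compounds go, is how 4-methoxybenzyl, a benzyl bearing a carboxylic acid, or a longer chain carrying the 2-methoxybenzyl amine would read.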